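The compounds below may be only part of what the source reports. "The series", "measured", "known", "first", "only" and "open" are said of these compounds alone.

Measured in a functional assay on HepG2 cells (Homo sapiens) for cytotoxicity, read by MTT assay; on this read-out higher numbers stand for weaker inhibition and lower numbers for stronger inhibition:
- Compound 1 `COc1cccc(C(=O)Oc2cc(/C=C/C(=O)c3ccc(OC)c4c3OC(C)(C)C=C4)ccc2OC)c1`: 870 nM
- Compound 2 `COc1ccc(/C=C/C(=O)c2ccc(OC)c3c2OC(C)(C)C=C3)cc1OC(=O)c1ccc(Br)cc1`: 680 nM

Among the compounds with values here, compound 2 cannot be separated from the only other measured compound, as a 1.3-fold lower number from compound 1 to compound 2 (0.11 log units; within the scatter) shows. Compound 3 `COc1ccc(/C=C/C(=O)Oc2cc(/C=C/C(=O)c3ccc(OC)c4c3OC(C)(C)C=C4)ccc2OC)cc1` carries 2-(4-methoxyphenyl)ethenyl in place of 4-bromophenyl on a carbonyl carbon. Within the data shown here, the one measured step at this carbonyl carbon, a 1.3-fold lower number from compound 1 to compound 2 (0.11 log units; within the scatter), exchanged 3-methoxyphenyl for 4-bromophenyl and stayed within the scatter. Among the measured compounds shown here, no measured step tests an ethenyl group here, so the expectation is loose. The expected change is small, within the scatter: a 1.0-fold higher number from compound 2 to compound 3 (0.01 log units; within the scatter). Compound 3 is estimated at 700 nM, with an expected range of 300 nM to 1600 nM.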

Compound 3, half-maximal inhibitory concentration: 430 nM
The estimate for compound 3 lay 1.6-fold (0.21 log units) above the measured number; the measured number falls inside the stated range.
By their numbers in this assay, from the lowest: compounds 3, 2 and 1 (each within the scatter of the next, the first and the last beyond it).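

In this assay, within the data shown here, 2-(4-methoxyphenyl)ethenyl in place of 3-methoxyphenyl gives a 2.0-fold lower number from compound 1 to compound 3 (0.31 log units; beyond the scatter), the first step on this carbonyl carbon to pass the scatter, though only modestly. The same group in place of 4-bromophenyl gives a 1.6-fold lower number from compound 2 to compound 3 (0.20 log units; within the scatter), so those two groups cannot be told apart here. No available evidence explains these steps.

The compounds shown do not separate the contribution of the double bond from that of the methoxy group. From the compounds shown here alone, how an amine or a carboxylic acid on this carbonyl carbon would behave also stays open.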